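Ring amine variations on a coumarin-ether series

This account rests on a few compounds, and the source may have more. Where it says the series, first, only, none or still open, it means among the compounds named here.

Compound 1 `COc1cc2ccc(=O)oc2cc1OCC(O)CN1CCCC1` and compound 2 `COc1cc2ccc(=O)oc2cc1OCC(O)CN1CCCCC1` share one core and differ only in the amine at the chain end. In a functional assay on HUVEC cells (Homo sapiens) for inhibition, read by MTT assay, with a stated time of 24 h, tested at 10 uM (on this read-out lower numbers stand for less inhibition of growth and higher numbers for more inhibition of growth at the one concentration tested), compound 1 gives 0.5%, and in this assay compound 2 gives 31.4%. Within the data shown here, the step of a number 30.9 percentage points higher from compound 1 to compound 2 (beyond the scatter) is the only measured change so far; it leaves compound 2 as the higher of the two numbers, with compound 1 below it beyond the scatter. Compound 3 `COc1cc2ccc(=O)oc2cc1OCC(O)CNC(C)C` is not yet measured; its difference from compound 2 is isopropylamino in place of piperidin-1-yl on a saturated chain carbon, two bonds along the chain from an oxygen on a saturated carbon. Among the measured compounds shown here, the one measured step bears on this only loosely: it shows that changing the amine can move the number a lot, but it went from a smaller ring to a larger one, whereas here the ring is removed entirely. The expectation for compound 3 is a drop, a number 21.4 percentage points lower from compound 2 to compound 3 (beyond the scatter), so compound 3 is estimated at 10% in this assay, with a range from -5% to 35%.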

Compound 3, percent growth inhibition at one concentration: 0.1%
Compound 3: the middle estimate sits 9.9 percentage points above what was measured; measured number inside the range.
By their numbers in this assay, from the lowest: compounds 3 and 1 (each within the scatter of the next); then compound 2.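

In this assay the step of a number 31.3 percentage points lower from compound 2 to compound 3 (beyond the scatter) shows that the growth inhibition seen with piperidin-1-yl on this saturated chain carbon does not carry over to the open-chain isopropylamino group. The step of a number 0.4 percentage points lower from compound 1 to compound 3 (within the scatter) places isopropylamino with pyrrolidin-1-yl, so among these three amines only piperidin-1-yl stands apart. Nothing on hand accounts for this difference between the amines.

Still open, on these data alone, is whether the piperidin-1-yl result reflects ring size alone or something particular to that ring, a question that morpholin-4-yl or azepan-1-yl at the same place would help to settle. Also open, as far as these compounds go, is how piperidin-1-yl would fare on a longer chain, and whether the pattern holds at concentrations other than the one tested.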